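Methylsulfanyl for Methylamino on a Shared Nucleoside Core

This account rests on a few compounds, and the source may have more. Where it says the series, first, only, none or still open, it means among the compounds named here.

Compound 2 `CNc1ncnc2c1c(-c1ccsc1)cn2[C@@H]1O[C@H](CO)[C@@H](O)[C@H]1O` is one of three analogues examined in a functional assay on HL-60 cells (Homo sapiens) for antiproliferative activity, read by XTT assay, with a stated time of 72 h; on this read-out higher numbers stand for weaker inhibition and lower numbers for stronger inhibition. In this assay compound 2 gives > 20000 nM, which is a limit of the assay and not a number. Compound 1 `CNc1ncnc2c1c(I)cn2[C@@H]1O[C@H](CO)[C@@H](O)[C@H]1O` likewise gives > 20000 nM, a limit. Compound 3 `CNc1ncnc2c1c(-c1ccoc1)cn2[C@@H]1O[C@H](CO)[C@@H](O)[C@H]1O` gives > 15000 nM, also a limit. The measured steps a step that the two limits leave unreadable from compound 1 to compound 2, a step that the two limits leave unreadable from compound 1 to compound 3 and a step that the two limits leave unreadable from compound 2 to compound 3 are therefore all unreadable in size, and none of them touches the methylamino group. Compound 4 `CSc1ncnc2c1c(-c1ccsc1)cn2[C@@H]1O[C@H](CO)[C@@H](O)[C@H]1O` differs from compound 2 by methylsulfanyl in place of methylamino on an aromatic carbon. Among the compounds with values here, with every neighbour sitting at the limit of > 20000 nM in this assay, at which 2 of the 3 values shown sit, or (the limit of > 15000 nM in this assay, at which 1 of the 3 values shown sits), no step bears on this change, so compound 4 is expected to show a number no higher from compound 2 to compound 4 (the limit leaves the size open), no change beyond the scatter. Compound 4 is estimated at 20000 nM, within 5000 nM to 40000 nM, and most likely again a limit.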

Compound 4, half-maximal inhibitory concentration: 4590 nM
For compound 4 the middle estimate is 4.4-fold (0.64 log units) above the measured one; measured number outside the range, below it.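

Within the data shown here, with thiophen-3-yl held fixed, methylsulfanyl in place of methylamino, next to the ring nitrogen, is the first change here that registers in this assay, with an at least 4.3-fold lower number from compound 2 to compound 4 (0.63 log units; beyond the scatter). Going by these compounds, the steps among compound 1, compound 2 and compound 3 cannot be read, whereas compound 4 falls clear of the limit shared by compound 1 and compound 2: the limit of > 20000 nM in this assay, at which 2 of the 4 values shown sit. This shows that the read-out responds to a change at this position, though the full size of the step stays open.

The compounds shown leave open whether methylsulfanyl gives a similar step alongside iodo or furan-3-yl. They also leave open whether ethylsulfanyl, with its longer chain on the sulfur, or an unsubstituted amine at this position would behave like methylsulfanyl or like methylamino.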